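Bromocatechol oxazoles: a methoxy for an isopropyl

The compounds below may be only part of what the source reports. "The series", "measured", "known", "first", "only" and "open" are said of these compounds alone.

Measured so far, each a limit in an assay on isolated protein for inhibition of receptor-type tyrosine-protein phosphatase F (Homo sapiens); a higher number here means a weaker inhibitor, a lower number a stronger inhibitor:
compound 1 `Oc1cc(-c2ncc(-c3ccc(Oc4ccccc4)cc3)o2)c(Br)c(Br)c1O` — compound 1 gives the limit > 40000 nM.
compound 2 `Cc1ccc(Oc2ccc(-c3cnc(-c4cc(O)c(O)c(Br)c4Br)o3)cc2)cc1` — compound 2 gives the limit > 38900 nM.
compound 3 `CC(C)c1ccc(Oc2ccc(-c3cnc(-c4cc(O)c(O)c(Br)c4Br)o3)cc2)cc1` — compound 3 gives the limit > 36900 nM.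

Compound 3 stands nowhere readable on these numbers: its value in this assay is only a limit, and the two other values shown are limits as well (the limit of > 36900 nM in this assay, at which 1 of the 3 values shown sits, (the limit of > 38900 nM in this assay, at which 1 of the 3 values shown sits), (the limit of > 40000 nM in this assay, at which 1 of the 3 values shown sits)). The change now followed is methoxy in place of isopropyl on an aromatic carbon, giving compound 4 `COc1ccc(Oc2ccc(-c3cnc(-c4cc(O)c(O)c(Br)c4Br)o3)cc2)cc1`. The measured steps that bear on it are those at the same place: a step that the two limits leave unreadable from compound 1 to compound 2, a step that the two limits leave unreadable from compound 1 to compound 3 and a step that the two limits leave unreadable from compound 2 to compound 3, none of which yields a readable size, since each joins two limits. With every value shown sitting at a limit, there is nothing that points to a step of any direction beyond the scatter, and the estimate for compound 4 is that it, too, most probably returns a limit, a step that the limit leaves unreadable from compound 3 to compound 4. Compound 4 is therefore expected at about 40000 nM, with a range from 15000 nM to 100000 nM in this assay.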

Compound 4, half-maximal inhibitory concentration: > 37700 nM
Compound 4: a limit, no number (the forecaster's own chance of this, stated with the estimate: 85%); the middle value does not contradict the limit.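

In this assay compound 4 gives > 37700 nM, which is a limit. Among the compounds shown here, compound 1, compound 2 and compound 3 also sit at limits, so no step from or to compound 4 can be read. The compounds shown leave open whether any group at this place changes inhibition.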